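Sulfonylguanidine series: chloro substitution on the aryl oxadiazole

The source may hold more compounds than are shown below. What is called first, only, known or untested is meant among the compounds shown, and "the series" means these compounds.

Measured compounds:
compound 1 `N=C(NO)NS(=O)(=O)c1cc(-c2nnc(-c3ccc(Cl)cc3)s2)c(Cl)cc1SCc1ccccc1` 1990 nM
compound 2 `COc1cc(CSc2cc(Cl)c(-c3nc(-c4ccccc4)no3)cc2S(=O)(=O)NC(=N)NO)cc(OC)c1OC` 4470 nM
compound 3 `N=C(NO)NS(=O)(=O)c1cc(-c2nc(-c3ccccc3)no2)c(Cl)cc1SCc1ccccc1` 1400 nM

In a functional assay on UO-31 cells (Homo sapiens) (on this read-out lower numbers stand for stronger inhibition of growth and higher numbers for weaker inhibition of growth), compound 2 gives 4470 nM, the highest of the three numbers; the nearest is compound 1 with 1990 nM, and the furthest is compound 3 with 1400 nM. Going by the values given here, the only single-point step among the measured compounds is a 3.2-fold lower number from compound 2 to compound 3 (0.50 log units; beyond the scatter), which concerns the benzylic substituent and not the aryl oxadiazole.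

Compound 4 `COc1cc(CSc2cc(Cl)c(-c3nc(-c4ccc(Cl)cc4)no3)cc2S(=O)(=O)NC(=N)NO)cc(OC)c1OC` differs from compound 2 by chloro in place of hydrogen on an aromatic carbon. Among the compounds with values here, no measured pair isolates this change: compound 1 and compound 3 differ both in the chloro and in the five-membered heteroaryl, and their values lie within the usual scatter of each other, so they carry no signal for the chloro alone. Within the data shown here, with no bearing step, no shift beyond the scatter is expected for this assay.

Compound 4 is therefore estimated at 4000 nM in this assay, with a range of 1800 nM to 9000 nM. This estimate corresponds to an expected step of a 1.1-fold lower number from compound 2 to compound 4 (0.05 log units; within the scatter).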

Compound 4, concentration for 50% growth inhibition: 3160 nM
Compound 4: middle estimate off by 1.3-fold (0.10 log units), on the high side; low and high end bracket the measured number.
By their numbers in this assay, from the lowest: compounds 3, 1, 4 and 2 (each within the scatter of the next, the first and the last beyond it).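

In this assay, the change from phenyl to 4-chlorophenyl now has a direct reading, free of any change in the five-membered heteroaryl: a 1.4-fold lower number from compound 2 to compound 4 (0.15 log units; within the scatter). The two compounds cannot be told apart, so chloro in place of hydrogen at this place, para to a large group, gives no signal on the 3,4,5-trimethoxyphenyl background. No outside data bear on this result.

From the compounds shown here alone, this reading rests on a single pair, so it remains open whether the same holds with the phenyl group of compound 3 in place of 3,4,5-trimethoxyphenyl. Also open, going by these compounds, is whether a different group at this place on the ring, such as methoxy, an amine or a carboxylic acid, would give a step beyond the scatter.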